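From Bromine to Chlorine on the Fused Ring

A few compounds are considered here, and "the series" means these few. Any claim that something is new, unique, unknown or untested is made for them only; others in the source may bear on it.

Compound 2 `COc1ccc(C2=NN(C3=NC(=O)/C(=C4\C(=O)Nc5ccc(Br)cc54)S3)C(c3ccc(OC)cc3)C2)cc1` gives the lowest of the two numbers recorded in a functional assay on cells (Cancer cell lines, Homo sapiens) for cytotoxicity, read by sulforhodamine B assay, with a stated time of 48 h (on this read-out lower numbers stand for stronger inhibition of growth and higher numbers for weaker inhibition of growth), namely 405 nM. For the measured compounds named here, compound 1 `COc1ccc(C2=NN(C3=NC(=O)/C(=C4\C(=O)Nc5ccccc54)S3)C(c3ccc(OC)cc3)C2)cc1` gives 89200 nM in this assay, and the only measured step, a 220-fold lower number from compound 1 to compound 2 (2.34 log units; beyond the scatter), shows how much a single halogen at this place can matter. Compound 3 `COc1ccc(C2=NN(C3=NC(=O)/C(=C4\C(=O)Nc5ccc(Cl)cc54)S3)C(c3ccc(OC)cc3)C2)cc1` differs from compound 2 by chloro in place of bromo on an aromatic carbon. The measured step bears only indirectly on this swap, since both halogens occupy the same place, so only a small change, within the scatter, is expected: a 1.5-fold higher number from compound 2 to compound 3 (0.17 log units; within the scatter). Compound 3 is therefore estimated at 600 nM, between 150 nM and 2500 nM.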

Compound 3, concentration for total growth inhibition: 420 nM
Compound 3: middle estimate off by 1.4-fold (0.15 log units), on the high side; the measured number falls inside the stated range.
By their numbers in this assay, from the lowest: compounds 2 and 3 (each within the scatter of the next); then compound 1.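

Chlorine serves at this place as well as bromine does: a 1.0-fold higher number from compound 2 to compound 3 (0.02 log units; within the scatter) puts the two halogens within the scatter of each other. With a 210-fold lower number from compound 1 to compound 3 (2.33 log units; beyond the scatter) as well, the large drop from the unsubstituted compound is not tied to bromine alone, but holds for both halogens on this aromatic carbon. Nothing shown explains why either halogen has this effect. From the compounds shown here alone, whether fluoro, or a non-halogen such as methyl or an amine, would do the same here stays open. So does whether either halogen would matter as much elsewhere on this ring.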